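Positional fluorine shift on the benzyl of a cytotoxicity series

The source may hold more compounds than are shown below. What is called first, only, known or untested is meant among the compounds shown, and "the series" means these compounds.

Measured so far:
compound 1 `COc1cccc2c1c(C(=O)/C=C(\O)C(=O)O)cn2Cc1cc(F)ccc1F`: 46200 nM
compound 2 `CCOC(=O)/C(O)=C/C(=O)c1cn(Cc2cccc(F)c2)c2cccc(OC)c12`: 63200 nM

In an ADME assay on MT4 cells (Homo sapiens) for cytotoxicity, read by MTT assay (a lower number here means that less compound is tolerated, a higher number that more compound is tolerated), compound 1 gives 46200 nM and compound 2 gives 63200 nM. For the measured compounds named here, no single-point step joins these two, and their numbers lie within the usual scatter of each other, so compound 1 is not set apart from compound 2 on this read-out; it simply stands at one end of a pair that cannot be ordered.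

Compound 3 `COc1cccc2c1c(C(=O)/C=C(\O)C(=O)O)cn2Cc1cc(F)cc(F)c1` has not yet been run in this assay. It differs from compound 1 only in the arrangement of the same atoms: 3,5-difluorophenyl in place of 2,5-difluorophenyl on a saturated chain carbon bound to an aromatic nitrogen. Going by the values given here, no measured step of this kind exists in the set, so the expectation rests on the fact that the shared core and the carboxylic acid end are untouched.

The step from compound 1 to compound 3 in this assay is expected to be small, a 1.1-fold higher number from compound 1 to compound 3 (0.03 log units; within the scatter), in no preferred direction beyond the scatter. Compound 3 is therefore estimated at 50000 nM, with a plausible range from 20000 nM to 120000 nM.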

Compound 3, half-maximal cytotoxic concentration: 29500 nM
The estimate for compound 3 lay 1.7-fold (0.23 log units) above the measured number; measured number inside the range.
By their numbers in this assay, from the lowest: compounds 3, 1 and 2 (each within the scatter of the next, the first and the last beyond it).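

In this assay, the exchange of 2,5-difluorophenyl for 3,5-difluorophenyl on a saturated chain carbon bound to an aromatic nitrogen gives a 1.6-fold lower number from compound 1 to compound 3 (0.19 log units; within the scatter), the first single-point step available at this position. With the shared core and the carboxylic acid end held constant, this rearrangement of the same atoms does not set compound 3 apart from compound 1 on this read-out, and the pair cannot be ordered. Nothing on hand bears on the size of this step or offers an explanation for it.

On these data alone, a single step between two difluorophenyl arrangements does not show how the read-out responds to a different group on this carbon, such as an unsubstituted phenyl or a chlorophenyl, so the sensitivity of the position as a whole remains open. Compound 2 differs from compound 1 and compound 3 in more than one place, so the contribution of its ethyl ester end cannot be separated from that of its benzyl group, and a matched ethyl ester of compound 1 or compound 3 would be needed to read it.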